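The source may hold more compounds than are shown below. What is called first, only, known or untested is meant among the compounds shown, and "the series" means these compounds.

Three analogues built on one shared core have been run in an assay on isolated protein for inhibition of glutathione S-transferase P (Homo sapiens), with a stated time of 10 min; on this read-out lower numbers stand for stronger inhibition and higher numbers for weaker inhibition. Compound 1 `O=C(CCC(=O)OCCCCCCSc1ccc([N+](=O)[O-])c2nonc12)Nc1ccccc1` gives 10200 nM. Compound 2 `O=C(CCC(=O)OCCCCCCSc1ccc([N+](=O)[O-])c2nonc12)Nc1cccc(Cl)c1` gives 28800 nM in this assay, and compound 3 `O=C(CCC(=O)OCCCCCCSc1ccc([N+](=O)[O-])c2nonc12)Nc1ccc(Br)cc1` gives 5090 nM. Compound 3 holds the lowest of the three numbers. Its nearest neighbour stays within the scatter: a 2.0-fold lower number from compound 1 to compound 3 (0.30 log units; within the scatter). The other gap is beyond it: a 5.7-fold lower number from compound 2 to compound 3 (0.75 log units; beyond the scatter).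

Compound 4 `O=C(CCC(=O)OCCCCCCSc1ccc([N+](=O)[O-])c2nonc12)Nc1ccc(C(F)(F)F)cc1` has not yet been measured in this assay. It differs from compound 3 in one place: trifluoromethyl in place of bromo on an aromatic carbon. Going by the values given here, no measured step exchanges bromo for trifluoromethyl, so the only guidance comes from the two substituent steps already seen, a 2.0-fold lower number from compound 1 to compound 3 (0.30 log units; within the scatter) and a 2.8-fold higher number from compound 1 to compound 2 (0.45 log units; beyond the scatter), both modest, and the bromo step itself within the scatter. Compound 4 is therefore expected to land close to compound 3, with a 1.2-fold higher number from compound 3 to compound 4 (0.07 log units; within the scatter) expected to stay within the usual scatter. The estimate for compound 4 in this assay is 6000 nM, with a range from 2500 nM to 15000 nM.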

Compound 4, half-maximal inhibitory concentration: 5050 nM
Estimate against measurement, compound 4: 1.2-fold (0.07 log units) above; measured number inside the range.
By their numbers in this assay, from the lowest: compounds 4, 3 and 1 (each within the scatter of the next, the first and the last beyond it); then compound 2.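

In this assay the place para to a large group accepts trifluoromethyl and bromo alike: the result is a 1.0-fold lower number from compound 3 to compound 4 (0.00 log units; within the scatter) even though four heavy atoms enter where one leaves. Measured from hydrogen, the trifluoromethyl exchange gives a 2.0-fold lower number from compound 1 to compound 4 (0.31 log units; beyond the scatter) and so lies just beyond the scatter where the bromo exchange lies within it, although compound 3 and compound 4 themselves cannot be told apart. Compound 4 also keeps the wide gap seen for compound 3 against the chloro analogue, with a 5.7-fold lower number from compound 2 to compound 4 (0.76 log units; beyond the scatter) as the step, so both 4-substituted phenyl groups stand apart from 3-chlorophenyl.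

As far as these compounds go, whether an amine or a carboxylic acid at this place would read like bromo stays open, as does what trifluoromethyl would give where compound 2 carries its chloro. No evidence at hand accounts for the match between bromo and trifluoromethyl.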